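Thiophen-2-yl in place of 4-fluorophenyl on an inactive compound

The source may report more compounds than this note shows. Statements on the series, on what has been measured and on what is new or still open speak of the compounds shown alone.

Compound 1 `O=C(CC(c1ccc(Cl)cc1)C(C(=O)Nc1ccccn1)C(=O)Nc1ccccn1)c1ccccc1` gives 18900 nM
Compound 2 `O=C(CC(c1ccc(F)cc1)C(C(=O)Nc1ccccn1)C(=O)Nc1ccccn1)c1ccccc1` gives "not active" (no number reported)

In a functional assay on NCI-H460 cells (Homo sapiens) for inhibition, read by MTT assay, with a stated time of 48 h (a lower number here means a stronger inhibitor, a higher number a weaker inhibitor), compound 2 has no number and is recorded only as "not active" (no number reported) in the results. In this assay, among the compounds with values here, compound 1 gives 18900 nM and is the only one of the pair with a measured potency.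

Compound 3 `O=C(CC(c1cccs1)C(C(=O)Nc1ccccn1)C(=O)Nc1ccccn1)c1ccccc1` has not yet been measured. The change is thiophen-2-yl in place of 4-fluorophenyl on a saturated chain carbon bound to two saturated chain carbons, which means thiophen-2-yl in place of 4-fluorophenyl on a saturated chain carbon bound to two saturated chain carbons. The rest of the shared core stays the same.

Within the data shown here, no step between measured compounds is available to scale this change, and compound 2 offers no numerical starting point. No large gain is therefore expected in this assay for this step. Among the measured compounds shown here, the only number to lean on is that of compound 1 at 18900 nM and compound 3 is expected to stay in that weak region or to be reported without a number as well. The estimated value for compound 3 is 25000 nM with an expected range from 10000 nM to 60000 nM in this test.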

Compound 3, half-maximal inhibitory concentration: "not active" (no number reported)
For compound 3 the study gives words and no number, so the estimate cannot be set against anything.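

In this assay compound 2 and compound 3 are both recorded only as "not active", so no step can be read between them. No measured evidence shown bears on this result. The compounds shown leave open how thiophen-2-yl and 4-fluorophenyl compare in this assay, since neither compound has a number.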